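A few compounds are considered here, and "the series" means these few. Any claim that something is new, unique, unknown or untested is made for them only; others in the source may bear on it.

Among the compounds with values here, in an ADME assay on MT4 cells (Homo sapiens) for cytotoxicity, read by MTT assay, with a stated time of 4 days (on this read-out higher numbers stand for lower toxicity in this test and lower numbers for higher toxicity in this test), compound 1 `CCCN(C)c1nc(Cc2c(F)cccc2F)cc(=O)[nH]1` gives 85000 nM, the only true number so far. Compound 2 `O=c1cc(Cc2c(F)cccc2N2CCCC2)nc(N2CCCC2)[nH]1` reads > 73000 nM, which is a limit of the assay. Compound 3 `CCCN(C)c1nc(Cc2c(F)cccc2F)c(C)c(=O)[nH]1` reads > 81000 nM, which is also a limit, so its place in the series is known only as a limit.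

The next change leads to compound 4 `Cc1c(Cc2c(F)cccc2F)nc(N2CCCCC2)[nH]c1=O`: piperidin-1-yl in place of methyl(propyl)amino on an aromatic carbon. This puts piperidin-1-yl in place of methyl(propyl)amino on an aromatic carbon, between two ring nitrogen atoms.

Within the data shown here, the only measured step, a step that the limit leaves unreadable from compound 1 to compound 3, is methyl in place of hydrogen on an aromatic carbon, so it involves a different part of the structure and gives no readable size. Among the measured compounds shown here, no measured step covers this exchange of amino groups. With compound 1 at 85000 nM as the only numerical anchor, no shift beyond the scatter is expected in this assay, in either direction. The expected change is an at least 1.0-fold lower number from compound 3 to compound 4 (0.03 log units; that floor lies within the scatter), and another limit reading is also expected to be quite possible. Compound 4 is estimated at 75000 nM, with an expected range from 35000 nM to 100000 nM.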

Compound 4, half-maximal cytotoxic concentration: > 78000 nM
Compound 4: no number, only a limit (the forecaster's own chance of this, stated with the estimate: 60%); middle value at least 1.0-fold (0.01 log units) from the limit.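

In this assay compound 3 and compound 4 both read as limits, so no step can be read for piperidin-1-yl in place of methyl(propyl)amino. Compound 4 gives > 78000 nM, which is a limit of the assay. The compounds shown leave open the true half-maximal cytotoxic concentrations of compound 3 and compound 4, and whether this exchange shifts the read-out at all.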